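The compounds below may be only part of what the source reports. "The series", "measured", "known", "first", "only" and "open" are said of these compounds alone.

Working notes on an ADME assay on L6 cells (Rattus norvegicus) for cytotoxicity; a lower number here means a stronger inhibitor, a higher number a weaker inhibitor. Among the measured compounds shown here, compound 1 `O=C(Nc1c(O)cccc1-c1nc2c(C(=O)O)cccc2o1)c1ccccn1` gives 30600 nM, and compound 2 `O=C(Nc1c(O)cccc1-c1nc2c(C(=O)O)cccc2o1)c1ncccc1F` gives 204000 nM, the higher of the two numbers so far. The next change leads from compound 2 to compound 3 `O=C(Nc1c(O)cccc1-c1nc2c(C(=O)O)cccc2o1)c1cnccn1`: pyrazin-2-yl in place of 3-fluoropyridin-2-yl on a carbonyl carbon. The change sits on a carbonyl carbon whose other neighbour is an amide-type nitrogen, and the rest of the structure stays the same.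

For the measured compounds named here, only one measured step bears on this change, a modest one with fluoro in place of hydrogen on an aromatic carbon: a 6.7-fold higher number from compound 1 to compound 2 (0.82 log units; beyond the scatter). Going by the values given here, compound 3 has no fluoro group, but pyrazin-2-yl has no measured precedent, so the reversal of that step can only be partial guidance. A modest move to a lower number is therefore expected in this assay, of similar or smaller size than that step. The expected change is a 2.9-fold lower number from compound 2 to compound 3 (0.46 log units; beyond the scatter). For compound 3 the estimated value is 70000 nM, with an expected range of 25000 nM to 200000 nM.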

Compound 3, half-maximal inhibitory concentration: 94400 nM
Estimate against measurement, compound 3: 1.3-fold (0.13 log units) below, within the range that was stated.
By their numbers in this assay, from the lowest: compound 1; then compound 3; then compound 2.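

In this assay, pyrazin-2-yl in place of 3-fluoropyridin-2-yl on the carbonyl carbon gives a 2.2-fold lower number from compound 2 to compound 3 (0.33 log units; beyond the scatter) but does not restore the number of the unsubstituted ring, as pyrazin-2-yl in place of pyridin-2-yl gives a 3.1-fold higher number from compound 1 to compound 3 (0.49 log units; beyond the scatter) in the same assay. Among these three compounds, both departures from pyridin-2-yl, the fluoro group and the second ring nitrogen of pyrazin-2-yl, therefore lead to a higher number, and compound 1 remains the lowest. Nothing on hand accounts for these differences.

The compounds shown leave open whether phenyl, or pyridin-2-yl carrying methyl or methoxy instead of fluoro, on this carbonyl carbon would stay close to compound 1 or move towards compound 2 and compound 3. They also leave open how these groups behave once the carboxylic acid of the shared core is replaced by an ester or an amide.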